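The source may report more compounds than this note shows. Statements on the series, on what has been measured and on what is new or still open speak of the compounds shown alone.

In a functional assay on A-375 cells (Homo sapiens) for cytotoxicity, read by MTT assay (a higher number here means a weaker inhibitor, a lower number a stronger inhibitor), three esters sharing one core have been measured. Compound 1 (`COc1ccc(/C=C/C(=O)c2ccc(OC)c3c2OC(C)(C)C=C3)cc1OC(=O)C(C)C`) gives 310 nM with isopropyl on a carbonyl carbon. Compound 2 (`COc1ccc(/C=C/C(=O)c2ccc(OC)c3c2OC(C)(C)C=C3)cc1OC(=O)CCl`) gives 450 nM with chloromethyl in that place. Compound 3 (`COc1ccc(/C=C/C(=O)c2ccc(OC)c3c2OC(C)(C)C=C3)cc1OC(=O)C1CC1`) gives 380 nM with cyclopropyl there, which leaves it within the scatter of both others.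

Compound 4 (`COc1ccc(/C=C/C(=O)c2ccc(OC)c3c2OC(C)(C)C=C3)cc1OC(=O)c1ccc(Br)cc1`) carries 4-bromophenyl in place of cyclopropyl on a carbonyl carbon and has not yet been measured. Going by the values given here, three measured steps bear on this change, all of them exchanges of the group on the same carbonyl carbon. Chloromethyl in place of isopropyl gave a 1.5-fold higher number from compound 1 to compound 2 (0.16 log units; within the scatter) while cyclopropyl in place of isopropyl gave a 1.2-fold higher number from compound 1 to compound 3 (0.09 log units; within the scatter) and cyclopropyl in place of chloromethyl gave a 1.2-fold lower number from compound 2 to compound 3 (0.07 log units; within the scatter) in turn. None of these steps brings in an aromatic ring, so they guide this change only loosely. The estimated step is a 1.1-fold higher number from compound 3 to compound 4 (0.05 log units; within the scatter) and so none beyond the scatter is expected. Compound 4 is estimated at 430 nM with an expected range from 160 nM to 1200 nM as a deliberately wide span.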

Compound 4, half-maximal inhibitory concentration: 420 nM
The estimate for compound 4 lay 1.0-fold (0.01 log units) above the measured number, within the range that was stated.
By their numbers in this assay, from the lowest: compounds 1, 3, 4 and 2 (each within the scatter of the next).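

In this assay, 4-bromophenyl in place of cyclopropyl on the carbonyl carbon gave a 1.1-fold higher number from compound 3 to compound 4 (0.04 log units; within the scatter), in place of chloromethyl it gave a 1.1-fold lower number from compound 2 to compound 4 (0.03 log units; within the scatter), and in place of isopropyl it gave a 1.4-fold higher number from compound 1 to compound 4 (0.13 log units; within the scatter). The earlier compounds shown here carried only non-aromatic groups here, whereas compound 4 shows that a six-membered aromatic ring of carbon only, with 7 heavy atoms against the 3 of cyclopropyl, leaves the number within the scatter of all three other esters, so across these four compounds no exchange at this position has yet moved the number beyond the scatter. Nothing measured here accounts for this flat result.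

The compounds shown leave open whether any group on this carbonyl carbon can move the number beyond the scatter, for example an amine, a carboxylic acid or a longer chain, or a phenyl ring without the bromine. They also leave open whether the ester linkage itself matters, as every compound shown keeps it and none carries an amide in its place.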